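Urea series, aryl-group variation, aorta inhibition

This account rests on a few compounds, and the source may have more. Where it says the series, first, only, none or still open, it means among the compounds named here.

Measured so far in a functional assay (aorta) for inhibition, with Rattus norvegicus as the target; on this read-out lower numbers stand for stronger inhibition and higher numbers for weaker inhibition:
compound 1 `CC(C)(C)c1ccc(C#N)cc1NC(=O)Nc1ccccc1` gives 1700000 nM
compound 2 `CC(C)(C)c1ccc(C#N)cc1NC(=O)Nc1ccncc1` gives 7800000 nM
compound 3 `CC(C)(C)c1ccc(C#N)cc1NC(=O)Nc1cnccn1` gives 15300000 nM

Compound 3 shows the highest number of the three; its step from compound 1 is a 9.0-fold higher number from compound 1 to compound 3 (0.95 log units; beyond the scatter), while its step from compound 2 is a 2.0-fold higher number from compound 2 to compound 3 (0.29 log units; within the scatter). Compound 4 `CC(C)(C)c1ccc(C#N)cc1NC(=O)Nc1ccc(Cl)nc1` differs from compound 3 by 6-chloropyridin-3-yl in place of pyrazin-2-yl on an amide-type nitrogen. The relevant steps run the other way: going from phenyl toward ring-nitrogen aryl groups raised the number, as in a 4.6-fold higher number from compound 1 to compound 2 (0.66 log units; beyond the scatter) and a 9.0-fold higher number from compound 1 to compound 3 (0.95 log units; beyond the scatter). Since the entering group carries one ring nitrogen rather than two, a modest move toward lower numbers is expected, roughly a 3.4-fold lower number from compound 3 to compound 4 (0.53 log units; beyond the scatter). Compound 4 in this assay is therefore estimated at 4500000 nM, with a range of 1500000 nM to 13000000 nM.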

Compound 4, half-maximal inhibitory concentration: 1600000 nM
The estimate for compound 4 lay 2.8-fold (0.45 log units) above the measured number; measured number inside the range.
By their numbers in this assay, from the lowest: compounds 4 and 1 (each within the scatter of the next); then compounds 2 and 3 (each within the scatter of the next).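

In this assay, a ring nitrogen in the aryl group on the amide-type nitrogen does not always go with a higher number: 6-chloropyridin-3-yl gives (a 9.6-fold lower number from compound 3 to compound 4 (0.98 log units; beyond the scatter)) and (a 4.9-fold lower number from compound 2 to compound 4 (0.69 log units; beyond the scatter)). Compound 4 therefore goes against the trend seen with compound 2 and compound 3, and it cannot be separated from the phenyl compound (a 1.1-fold lower number from compound 1 to compound 4 (0.03 log units; within the scatter)). No supporting data bear on why this group differs from the other ring-nitrogen groups.

The compounds shown leave open whether the chlorine or the place of the ring nitrogen accounts for the difference. Plain pyridin-3-yl and chlorophenyl would separate these two changes.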